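A few compounds are considered here, and "the series" means these few. Any claim that something is new, unique, unknown or untested is made for them only; others in the source may bear on it.

Series notes on the hydrazone set. In an ADME assay on J774 cells (Mus musculus, strain BALB/c) for cytotoxicity, read by resazurin assay, with a stated time of 72 h (a higher number here means that more compound is tolerated, a lower number that less compound is tolerated), compound 1 `CC(/C=N/Nc1ccc([N+](=O)[O-])cc1)=N\NC(=O)c1ccc(N)cc1` gives 75000 nM. In this assay, among the compounds with values here, compound 2 `CC(/C=N/N(C)c1ccc([N+](=O)[O-])cc1)=N\NC(=O)c1ccccc1O` gives 31500 nM, the lowest of the two numbers so far; compound 1 sits at the higher number, and the gap between the two lies beyond the scatter. Compound 1 and compound 2 differ in more than one place, so their two values show only where each stands and not a single-point step.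

Compound 3 `CC(/C=N/N(C)c1ccc([N+](=O)[O-])cc1)=N\NC(=O)c1ccc(N)cc1` is not yet measured in this assay. Relative to compound 2 the change is 4-aminophenyl in place of 2-hydroxyphenyl on a carbonyl carbon. Within the data shown here, no measured pair tracks this change alone. Compound 1, which gives 75000 nM in this assay, carries the same 4-aminophenyl group that compound 3 carries. A modest rise is expected, a 1.6-fold higher number from compound 2 to compound 3 (0.20 log units; within the scatter), possibly not beyond the scatter. For compound 3 the expected value in this assay is 50000 nM, within a range from 20000 nM to 120000 nM.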

Compound 3, half-maximal cytotoxic concentration: 51700 nM
Estimate against measurement, compound 3: 1.0-fold (0.01 log units) below, within the range that was stated.
By their numbers in this assay, from the lowest: compounds 2, 3 and 1 (each within the scatter of the next, the first and the last beyond it).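

In this assay the change on the carbonyl carbon now has a single-place reading: 4-aminophenyl in place of 2-hydroxyphenyl gives a 1.6-fold higher number from compound 2 to compound 3 (0.22 log units; within the scatter) and stays within the scatter. Within the data shown here, compound 3 also gives the first reading of methyl in place of hydrogen on a nitrogen on an aromatic ring, with a 1.5-fold lower number from compound 1 to compound 3 (0.16 log units; within the scatter) also within the scatter, so neither change alone separates its two compounds beyond the scatter. No evidence at hand bears on these two steps.

Going by these compounds, each change is read on one background only, so whether either step holds on another background stays open. Also open, on these data alone, is whether ethyl on that nitrogen, or 4-hydroxyphenyl or 4-carboxyphenyl on the carbonyl carbon, would give a step beyond the scatter.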